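The source may hold more compounds than are shown below. What is called first, only, known or untested is meant among the compounds shown, and "the series" means these compounds.

Measured compounds in a toxicity assay on Vero cells (Chlorocebus sabaeus) for cytotoxicity; on this read-out higher numbers stand for lower toxicity in this test and lower numbers for higher toxicity in this test:
- compound 1, `O=C(/C=C/c1ccc([N+](=O)[O-])o1)c1ccc(F)cc1`: 463000 nM
- compound 2, `Cc1ccc(C(=O)/C=C/c2ccc([N+](=O)[O-])o2)cc1`: 439000 nM
- compound 3, `O=C(/C=C/c1ccc([N+](=O)[O-])o1)c1ccc(OCc2ccc(F)cc2)cc1`: 430000 nM

Compound 3 stands together with compounds 1 and 2, not apart from them: the step of a 1.1-fold lower number from compound 1 to compound 3 (0.03 log units; within the scatter) and the step of a 1.0-fold lower number from compound 2 to compound 3 (0.01 log units; within the scatter) are both within the scatter, as is the step of a 1.1-fold lower number from compound 1 to compound 2 (0.02 log units; within the scatter) between the two others. Across the three substituents tried on the aryl ketone ring the read-out in this assay has not moved beyond the scatter.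

Compound 4, `O=C(/C=C/c1ccc([N+](=O)[O-])o1)c1ccc(OCc2cccc(Cl)c2)cc1`, is not yet measured. It differs from compound 3 by 3-chlorophenyl in place of 4-fluorophenyl on a saturated chain carbon bound to an oxygen on an aromatic ring. Going by the values given here, the steps that bear on this change are the two that introduce the (4-fluorobenzyl)oxy group, from compound 1 and from compound 2 to compound 3; both were within the scatter, and the step between the small substituents in compounds 1 and 2 was likewise. Among the compounds with values here, no measured step here separates a halogenated benzyl group from any other, so the data give no ground for a step beyond the scatter in either direction.

For compound 4 the number in this assay is therefore expected to stay near that of compound 3, the expected step of no change at the digits printed from compound 3 to compound 4 (within the scatter) being within the scatter. The estimate for compound 4 is 430000 nM, with a range from 250000 nM to 700000 nM.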

Compound 4, half-maximal cytotoxic concentration: 307000 nM
The estimate for compound 4 lay 1.4-fold (0.15 log units) above the measured number, within the range that was stated.
By their numbers in this assay, from the lowest: compounds 4, 3, 2 and 1 (each within the scatter of the next).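

In this assay, 3-chlorophenyl in place of 4-fluorophenyl on a saturated chain carbon bound to an oxygen on an aromatic ring gives a 1.4-fold lower number from compound 3 to compound 4 (0.15 log units; within the scatter) and so adds a second halogenated benzyl group to the series without a step beyond the scatter. Read against the small substituents, the (3-chlorobenzyl)oxy group gives a 1.4-fold lower number from compound 2 to compound 4 (0.16 log units; within the scatter) and a 1.5-fold lower number from compound 1 to compound 4 (0.18 log units; within the scatter) so that this group, like (4-fluorobenzyl)oxy, stands together with methyl and fluoro in this read-out, and all four compounds remain one group with no separation among them. No measured information on any property of these groups bears on this result.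

This change replaces the halogen and its ring position together, so the two cannot be read apart; a 4-chlorophenyl or 3-fluorophenyl group would be needed to separate them. Also open, going by these compounds, is whether the same flat picture would hold with an amine or a carboxylic acid on the benzyl ring, with a longer chain in place of the benzyl link, or with a replacement for the nitro group on the shared core.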